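Working notes: one methoxy step from compound 2 to compound 3

The source may report more compounds than this note shows. Statements on the series, on what has been measured and on what is new or still open speak of the compounds shown alone.

Among the compounds with values here, compound 2 `COc1ccc(C(=O)/C=C/c2cc(-c3cc(OC)c(OC)c(OC)c3)n[nH]2)cc1OC` holds the highest of the two numbers so far: in a functional assay on COLO 205 cells (Homo sapiens) for cytotoxicity, read by sulforhodamine B assay, with a stated time of 48 h, tested at 0.01 uM (a higher number here means a weaker effect of the compound at the concentration tested, a lower number a stronger effect), compound 2 gives 107%. Within the data shown here, compound 1 `COc1cc(-c2cc(/C=C/C(=O)c3ccc(N)cc3)[nH]n2)cc(OC)c1OC`, the only other measured member, gives 93% in this assay, and the difference between them is a number 14 percentage points higher from compound 1 to compound 2 (beyond the scatter). Compound 3 `COc1cc(C(=O)/C=C/c2cc(-c3cc(OC)c(OC)c(OC)c3)n[nH]2)cc(OC)c1OC` is the next member; its difference from compound 2 is methoxy in place of hydrogen on an aromatic carbon. Among the measured compounds shown here, the one measured step bears on it only loosely, since it swapped the whole group on the carbonyl carbon rather than adding a single methoxy, and it was itself modest. Both measured numbers sit close to no effect at this concentration, which leaves little room for a change in either direction. The expected step in this assay is therefore a number 5 percentage points lower from compound 2 to compound 3 (within the scatter), not beyond the scatter. For compound 3 the estimate in this assay is 102%, with a range from 86% to 116%.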

Compound 3, a percentage reported as activity, at one concentration (the size of the read-out at that concentration, not a potency): 103%
Compound 3: the middle estimate sits 1 percentage points below what was measured, within the range that was stated.
By their numbers in this assay, from the lowest: compounds 1, 3 and 2 (each within the scatter of the next, the first and the last beyond it).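

In this assay, methoxy in place of hydrogen gives a number 4 percentage points lower from compound 2 to compound 3 (within the scatter). Within the data shown here, this is the first single-group change on this ring: the earlier step replaced the whole group on the carbonyl carbon, whereas here a position ortho to a methoxy group and meta to a large group takes one more methoxy with no difference beyond the scatter at this one concentration. No measurement available here gives a reason for this result.

Going by these compounds, whether a hydroxy group or a longer ethoxy chain at this position would give a number beyond the scatter remains open. Also open, on these data alone, is whether compound 2 and compound 3 would separate at a higher concentration, since a single low-concentration read-out does not give a potency for either.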